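The source may report more compounds than this note shows. Statements on the series, on what has been measured and on what is new or still open speak of the compounds shown alone.

Compound 1, `COc1ccc(S(=O)(=O)N2CCC(N3CCC(C)CC3)CC2)cc1OC`: 138 nM
Compound 2, `CC(=O)Nc1ccc(S(=O)(=O)N2CCC(N3CCC(C)CC3)CC2)c2ccccc12`: 1100 nM
Compound 3, `COc1cc(C)c(S(=O)(=O)N2CCC(N3CCC(C)CC3)CC2)cc1C(C)C`: 3 nM

These three compounds share a common core and differ only in the aromatic ring attached to the sulfonyl group. They were tested in a functional assay on DLD-1 cells (Homo sapiens) for antiproliferative activity, read by CellTiter-Glo, with a stated time of 72 h; on this read-out lower numbers stand for stronger inhibition and higher numbers for weaker inhibition. Compound 1 gives 138 nM and stands second highest of the three numbers. Compound 2, with its acetamido-bearing fused ring, gives 1100 nM, a higher number beyond the usual scatter, so it is the weaker inhibitor of the two. Compound 3, whose ring carries three groups, gives 3 nM, a number far below that of compound 1, again well beyond the scatter.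

Compound 4, `COc1cccc(S(=O)(=O)N2CCC(N3CCC(C)CC3)CC2)c1`, is the next compound to be tested in this assay. It differs from compound 1 in one place: hydrogen in place of methoxy on an aromatic carbon. The ring of compound 4 thus carries fewer groups than either compound 1 or compound 3. Since compound 3, with its more heavily substituted ring, gives 3 nM while compound 1 gives 138 nM, taking a group away is expected to move the number upward, by a modest step somewhat beyond the scatter. The expected step from compound 1 to compound 4 is a 2.3-fold higher number from compound 1 to compound 4 (0.37 log units; beyond the scatter). Compound 4 is therefore expected to give about 320 nM in this assay, with a likely range from 110 nM to 950 nM.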

Compound 4, half-maximal inhibitory concentration: > 5000 nM
Compound 4 ended at the assay's limit; the forecaster's own chance of this, stated with the estimate: 3%; middle value at least 15-fold (1.19 log units) from the limit.
By their numbers in this assay, from the lowest: compound 3; then compound 1; then compound 2. At a limit, above all of these: compound 4.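

In this assay compound 4 gives > 5000 nM, which is a limit of the assay and not a number. Going by these compounds alone, putting hydrogen in place of the methoxy group, ortho to the remaining methoxy group and para to the large group, gives an at least 36-fold higher number from compound 1 to compound 4 (1.55 log units; beyond the scatter); this is the first pair here that differs in one place only, and it shows that this single position on the ring can by itself decide whether the compound reaches the measurable range. The step can be read only as a minimum, and its true size stays unknown, because compound 4 sits at a limit: the limit of > 5000 nM in this assay, at which 1 of the 4 values shown sits.

On these data alone, whether the methoxy group itself is needed, or whether a smaller or different group would serve as well, stays open: a methyl group, a chlorine atom or an amine at this place could tell these cases apart. The compounds shown also leave open what the remaining methoxy group contributes, and they give no measured reason for the large change seen on removing the other one.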